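The compounds below may be only part of what the source reports. "The series", "measured", "known", "first", "only" and "open" are said of these compounds alone.

In an assay on SH-SY5Y cells for inhibition of Voltage-dependent N-type calcium channel subunit alpha-1B (Homo sapiens), read by FLIPR and calcium flux, with stated times of 600 s and 300 s, in the presence of a further agent that is not named here (a higher number here means a weaker inhibitor, a lower number a stronger inhibitor), compound 2 `N=C(N)NCCCOc1ccc(CNc2nc3ccc(Oc4ccc(F)cc4)cc3s2)cc1` gives 244000 nM. Compound 1 `N=C(N)NCCCOc1ccc(CNc2nc3ccc(Oc4cccc(C(F)(F)F)c4)cc3s2)cc1` differs from compound 2 in that (3-(trifluoromethyl)phenyl in place of 4-fluorophenyl on an oxygen on an aromatic ring), and in this assay compound 1 gives 130000 nM, so that a 1.9-fold lower number from compound 2 to compound 1 (0.27 log units; within the scatter). Compound 3 `NCCCOc1ccc(CNc2nc3ccc(Oc4ccc(F)cc4)cc3s2)cc1` differs from compound 2 in that (a hydrogen atom in place of a group of 3 heavy atoms (1 carbon, 2 nitrogen; no ring), on an amine nitrogen); in this assay compound 3 gives 106000 nM, so that a 2.3-fold lower number from compound 2 to compound 3 (0.36 log units; beyond the scatter). Compound 4 `NCCCOc1ccc(CNc2nc3ccc(Oc4cccc(C(F)(F)F)c4)cc3s2)cc1` has not yet been measured; it differs from compound 3 in that (3-(trifluoromethyl)phenyl in place of 4-fluorophenyl on an oxygen on an aromatic ring), which is the same change, at the same place, as that between compound 2 and compound 1. A step of similar size is expected for compound 4 because the earlier step of a 1.9-fold lower number from compound 2 to compound 1 (0.27 log units; within the scatter) stayed small. Compound 4 is therefore estimated at 70000 nM, likely lying between 30000 nM and 160000 nM. The expected step is a 1.5-fold lower number from compound 3 to compound 4 (0.18 log units; within the scatter).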

Compound 4, half-maximal inhibitory concentration: 144000 nM
Beside the measured number, compound 4's estimate is 2.1-fold (0.31 log units) below it; the range from low to high includes it.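

In this assay, 3-(trifluoromethyl)phenyl in place of 4-fluorophenyl gives a 1.4-fold higher number from compound 3 to compound 4 (0.13 log units; within the scatter), and this step cannot be told apart from its earlier counterpart on the other core: the same change on two cores in this assay, a 1.9-fold lower number (0.27 log units; within the scatter) from compound 2 to compound 1 and a 1.4-fold higher number (0.13 log units; within the scatter) from compound 3 to compound 4, 2.5-fold (0.41 log units) apart, within the scatter of two such steps. The change on the amine nitrogen, now made with 3-(trifluoromethyl)phenyl in place, gives a 1.1-fold higher number from compound 1 to compound 4 (0.04 log units; within the scatter), and it too cannot be told apart from its counterpart: the same change on two cores in this assay, a 2.3-fold lower number (0.36 log units; beyond the scatter) from compound 2 to compound 3 and a 1.1-fold higher number (0.04 log units; within the scatter) from compound 1 to compound 4, 2.5-fold (0.41 log units) apart, within the scatter of two such steps. These gaps show no detectable dependence on the core, but they do not show that either change carries over with a fixed size or direction, and they rest on only these four compounds.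

Going by these compounds, it remains open whether a plain phenyl or a pyridine on that oxygen would give a clearly different number. The same holds for a longer chain ending in the amine, or a carboxylic acid in place of the amine.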